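Ester to acetamide exchange on the shared core

The compounds below may be only part of what the source reports. "The series", "measured", "known", "first", "only" and "open" are said of these compounds alone.

Measured so far in a functional assay for inhibition, with Homo sapiens as the target; on this read-out higher numbers stand for weaker inhibition and lower numbers for stronger inhibition:
compound 1 `CC(=O)N(C)c1ccc(Nc2nccc(-c3cccnc3)n2)cc1`: 900 nM
compound 2 `NS(=O)(=O)c1ccc(Nc2nccc(-c3cccnc3)n2)cc1`: 200 nM
compound 3 `CCOC(=O)c1ccc(Nc2nccc(-c3cccnc3)n2)cc1`: 12400 nM

Compound 3 is the weakest inhibitor of the three, beyond the scatter on both sides: a 14-fold higher number from compound 1 to compound 3 (1.14 log units; beyond the scatter) and a 62-fold higher number from compound 2 to compound 3 (1.79 log units; beyond the scatter). Compound 4 `CC(=O)Nc1ccc(Nc2nccc(-c3cccnc3)n2)cc1` is obtained by acetamido in place of ethoxycarbonyl on an aromatic carbon. Among the measured compounds shown here, no measured step exchanges exactly these two groups. For the measured compounds named here, the step that bears most on it is the one from compound 1 to compound 3, a 14-fold higher number from compound 1 to compound 3 (1.14 log units; beyond the scatter), since acetamido and acetyl(methyl)amino are close relatives; the move to compound 4 largely reverses that step. A large fall in the number is therefore expected, back toward the level of compound 1. Compound 4 is estimated at 800 nM, range 300 nM to 2500 nM, which means a 16-fold lower number from compound 3 to compound 4 (1.19 log units; beyond the scatter).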

Compound 4, half-maximal inhibitory concentration: 3600 nM
Compound 4: the middle estimate sits 4.5-fold (0.65 log units) below what was measured, outside the stated range (above it).
By their numbers in this assay, from the lowest: compound 2; then compound 1; then compound 4; then compound 3.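

In this assay the change at this position gives a 3.4-fold lower number from compound 3 to compound 4 (0.54 log units; beyond the scatter) and so recovers only part of the gap to the better compounds, while an 18-fold higher number from compound 2 to compound 4 (1.26 log units; beyond the scatter) leaves acetamido well short of sulfamoyl. The amide-type nitrogen itself counts: with the acetyl group unchanged, hydrogen in place of methyl gives a 4.0-fold higher number from compound 1 to compound 4 (0.60 log units; beyond the scatter) and the two acetyl amides are not interchangeable. Nothing available bears on the reason for these differences.

From the compounds shown here alone, whether an ethyl group on that nitrogen goes further than methyl stays open. So does whether a methanesulfonamide or a free amine at this position comes close to sulfamoyl.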